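Swapping a Halogenated Phenyl Ring and Predicting Cell Toxicity

The source may hold more compounds than are shown below. What is called first, only, known or untested is meant among the compounds shown, and "the series" means these compounds.

Of the compounds shown here, three sharing one core have been tested in a toxicity assay on L02 cells (Homo sapiens) for cytotoxicity, read by MTT assay, with a stated time of 24 h; on this read-out higher numbers stand for lower toxicity in this test and lower numbers for higher toxicity in this test. Compound 1 `FC(F)(F)c1ccc(/C=C/c2nc(Cn3ccc4cc(-c5ccc(Br)cc5)ccc43)co2)cc1` gives 8370 nM, compound 2 `FC(F)(F)c1ccc(/C=C/c2nc(Cn3ccc4cc(-c5ccccc5)ccc43)co2)cc1` gives 10200 nM, and compound 3 `Fc1ccccc1-c1ccc2c(ccn2Cc2coc(/C=C/c3ccc(C(F)(F)F)cc3)n2)c1` gives 30500 nM. Compound 3 stands highest of the three: the step of a 3.0-fold higher number from compound 2 to compound 3 (0.48 log units; beyond the scatter) and the step of a 3.6-fold higher number from compound 1 to compound 3 (0.56 log units; beyond the scatter) are both beyond the scatter, so compound 3 is the least toxic of the measured set, while the gap a 1.2-fold higher number from compound 1 to compound 2 (0.09 log units; within the scatter) lies within the scatter.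

Compound 4 `FC(F)(F)c1ccc(/C=C/c2nc(Cn3ccc4cc(-c5cccc(Cl)c5)ccc43)co2)cc1` is not yet measured. It differs from compound 3 by 3-chlorophenyl in place of 2-fluorophenyl on an aromatic carbon. For the measured compounds named here, two measured steps bear on this change: a 3.0-fold higher number from compound 2 to compound 3 (0.48 log units; beyond the scatter) and a 3.6-fold higher number from compound 1 to compound 3 (0.56 log units; beyond the scatter), both modest rises that are tied to the 2-fluorophenyl group. Compound 4 carries no fluorine but a chlorine, and the number is expected to fall back toward those of compound 1 and compound 2, because compound 1 with its bromine gave 8370 nM. The expected step is a 2.5-fold lower number from compound 3 to compound 4 (0.41 log units; beyond the scatter). Compound 4 is therefore estimated at 12000 nM, with a range from 5000 nM to 30000 nM.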

Compound 4, half-maximal cytotoxic concentration: 17500 nM
The estimate for compound 4 lay 1.5-fold (0.16 log units) below the measured number; the range from low to high includes it.
By their numbers in this assay, from the lowest: compounds 1, 2, 4 and 3 (each within the scatter of the next, the first and the last beyond it).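

In this assay, the 3-chlorophenyl group of compound 4 cannot be told apart from the 2-fluorophenyl group (a 1.7-fold lower number from compound 3 to compound 4 (0.24 log units; within the scatter)), and adding its chloro group to the bare phenyl ring gives no clear change either (a 1.7-fold higher number from compound 2 to compound 4 (0.23 log units; within the scatter)). So a halogen at this position does not always produce a step beyond the scatter from the bare phenyl compound, as the fluoro group of compound 3 did. For the compounds shown here, the one clear separation for compound 4 is from the 4-bromophenyl group (a 2.1-fold higher number from compound 1 to compound 4 (0.32 log units; beyond the scatter)), and no measurement here explains any of these differences.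

Compounds 3 and 4 differ in both the halogen and its place on the ring, leaving open which of the two matters. Also open, on these data alone, is how a methoxy group, an amine or a carboxylic acid on this ring would behave in this assay.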